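Thiophen-3-yl for furan-3-yl on an inactive nucleoside

The source may hold more compounds than are shown below. What is called first, only, known or untested is meant among the compounds shown, and "the series" means these compounds.

In a functional assay on CEM-DNR-bulk cells (Homo sapiens), read by MTT assay, with a stated time of 72 h (on this read-out lower numbers stand for stronger inhibition and higher numbers for weaker inhibition), compound 3 `COc1nc(N)nc2c1c(-c1ccoc1)cn2[C@@H]1O[C@H](CO)[C@@H](O)[C@H]1O` gives > 20000 nM, which is a limit of the assay and not a number. Compound 2 `Cc1nc(N)c2c(-c3ccccc3)cn([C@@H]3O[C@H](CO)[C@@H](O)[C@H]3O)c2n1` gives > 20000 nM, also a limit. Compound 1 `Nc1nc(N)c2c(-c3ccsc3)cn([C@@H]3O[C@H](CO)[C@@H](O)[C@H]3O)c2n1`, which carries thiophen-3-yl, gives > 20000 nM, again a limit. Compound 3 therefore has no measured potency of its own and shares its place with the other two, as the record shows (the limit of > 20000 nM in this assay, at which 3 of the 3 values shown sit).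

Compound 4 `COc1nc(N)nc2c1c(-c1ccsc1)cn2[C@@H]1O[C@H](CO)[C@@H](O)[C@H]1O` differs from compound 3 by one change, thiophen-3-yl in place of furan-3-yl on an aromatic carbon. Among the compounds with values here, no measured pair shows what such a change does in this assay. Within the data shown here, the only guide is compound 1, whose thiophen-3-yl group comes with > 20000 nM, a limit. The expected step that the limit leaves unreadable from compound 3 to compound 4 is therefore none beyond the scatter, in either direction. For compound 4 the estimate is 25000 nM, with an expected range of 10000 nM to 50000 nM, and the result will most likely be reported only as a limit.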

Compound 4, half-maximal inhibitory concentration: > 20000 nM
Compound 4: a limit, no number (the forecaster's own chance of this, stated with the estimate: 85%); the middle value does not contradict the limit.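

Within the data shown here, compound 4 sits at a limit, as do compound 3 and compound 1, so no step from either of them to compound 4 can be read in this assay: the limit of > 20000 nM in this assay, at which 4 of the 4 values shown sit. From the compounds shown here alone, what thiophen-3-yl in place of furan-3-yl, or methoxy in place of amino, does to potency there remains open.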